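This account rests on a few compounds, and the source may have more. Where it says the series, first, only, none or still open, it means among the compounds named here.

Series notes, cytotoxicity branch. In an ADME assay on MT4 cells (Homo sapiens) for cytotoxicity, read by MTT assay, with a stated time of 5 days (on this read-out lower numbers stand for higher toxicity in this test and higher numbers for lower toxicity in this test), compound 1 `Cc1cc(C)cc(S(=O)(=O)c2c(C(N)=O)[nH]c3ccc(Cl)cc23)c1` gives 13000 nM; compound 2 `Cc1cc(C)cc(S(=O)(=O)c2c(C(=O)NC3CNC3)[nH]c3ccc(Cl)cc23)c1` gives 37300 nM; compound 3 `Cc1cc(C)cc(S(=O)(=O)c2c(C(=O)N[C@H]3CCN(Cc4ccccc4F)C3)[nH]c3ccc(Cl)cc23)c1` gives 215000 nM. Compound 2 holds the second highest of the three numbers: its nearest neighbour is compound 1, its furthest compound 3. Among the measured compounds shown here, the only single-point step so far is a 2.9-fold higher number from compound 1 to compound 2 (0.46 log units; beyond the scatter), a modest rise on the amide-type nitrogen.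

The next compound, compound 4 `CCCS(=O)(=O)NC(=O)c1[nH]c2ccc(Cl)cc2c1S(=O)(=O)c1cc(C)cc(C)c1`, alters that same nitrogen again: propylsulfonyl in place of azetidin-3-yl on an amide-type nitrogen. For the measured compounds named here, no measured step covers a propylsulfonyl group anywhere, so the expectation rests on the one substitution at that position, a 2.9-fold higher number from compound 1 to compound 2 (0.46 log units; beyond the scatter), and on the fact that all three numbers in this assay sit within a narrow band. Because compound 2 gives 37300 nM and the step of a 2.9-fold higher number from compound 1 to compound 2 (0.46 log units; beyond the scatter) was modest, the expected step of a 1.3-fold lower number from compound 2 to compound 4 (0.12 log units; within the scatter) is none beyond the scatter. Compound 4 is estimated at 28000 nM in this assay, with a range from 9000 nM to 90000 nM.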

Compound 4, half-maximal cytotoxic concentration: 146000 nM
Estimate against measurement, compound 4: 5.2-fold (0.72 log units) below, outside the stated range (above it).
By their numbers in this assay, from the lowest: compound 1; then compound 2; then compounds 4 and 3 (each within the scatter of the next).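

Propylsulfonyl in place of azetidin-3-yl on the amide-type nitrogen gives a 3.9-fold higher number from compound 2 to compound 4 (0.59 log units; beyond the scatter) in this assay, so this nitrogen tolerates a substituent with no ring and no hydrogen-bond donors, and the number still moves upward. Against the amide hydrogen of compound 1, the same group gives an 11-fold higher number from compound 1 to compound 4 (1.05 log units; beyond the scatter), the first large step in the series, and compound 4 lies within the scatter of compound 3, although only compound 3 carries a ring on this nitrogen. No measured evidence here accounts for either step.

The compounds shown do not separate the contribution of the sulfonyl link from that of the propyl chain. A simple butanoyl group, a methylsulfonyl group or a longer alkylsulfonyl chain on this nitrogen would help to separate them.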